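A Mirror Image Tested Against Leukaemia Cells

The source may report more compounds than this note shows. Statements on the series, on what has been measured and on what is new or still open speak of the compounds shown alone.

compound 1 `CC1=CC(=O)[C@]2(O[C@@H]2C(=O)CC(C)C)C(=O)N1` — 1700 nM
compound 2 `CC(C)CC(=O)C1Oc2cc(Cc3ccccc3)[nH]c(=O)c2O1` — > 50000 nM

Within the data shown here, in a functional assay on HL-60 cells (Homo sapiens) for cytotoxicity, read by WST assay, with a stated time of 48 h (on this read-out higher numbers stand for weaker inhibition and lower numbers for stronger inhibition), compound 1 gives 1700 nM, the only number among the two values shown. For compound 2 the value > 50000 nM is a limit of the assay, not a number; (the limit of > 50000 nM in this assay, at which 1 of the 2 values shown sits). Compound 3 `CC1=CC(=O)[C@@]2(O[C@H]2C(=O)CC(C)C)C(=O)N1` differs from compound 1 only in configuration: the two compounds have the same atoms and bonds and differ only in configuration as drawn: 2 of 2 stereo elements differ (all stereocentres are inverted: mirror images); a stereocentre at a saturated ring carbon is drawn S in compound 1 and R in compound 3; a stereocentre at a saturated ring carbon is drawn S in compound 1 and R in compound 3. Among the measured compounds shown here, no measured step of this kind exists here, so the size of the change is open. A step toward weaker inhibition, beyond the scatter, is expected from compound 1 to compound 3, namely a 3.5-fold higher number from compound 1 to compound 3 (0.55 log units; beyond the scatter). Compound 3 is therefore estimated at 6000 nM, within 1200 nM to 40000 nM.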

Compound 3, half-maximal inhibitory concentration: 1600 nM
The estimate for compound 3 lay 3.8-fold (0.57 log units) above the measured number, and the stated range covers the measured number.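

In this assay, inverting both stereocentres gives a 1.1-fold lower number from compound 1 to compound 3 (0.03 log units; within the scatter). Among these compounds, this is the first measured step at these two stereocentres, and it shows that, for this pair of mirror images, the cell-killing read-out does not separate one drawn configuration from the other. A reversal of the whole arrangement is therefore tolerated here, at least in these cells.

What the compounds shown leave open is the effect of inverting just one of the two stereocentres. Also open, on these data alone, is how an amine or a longer chain on the shared core would behave.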